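The source may hold more compounds than are shown below. What is called first, only, known or untested is meant among the compounds shown, and "the series" means these compounds.

Of the compounds shown here, three that share one core have been tested in a functional assay on Ehrlich cells (Mus musculus) for antiproliferative activity, read by trypan blue exclusion, with a stated time of 2 h, tested at 100 ug/mL; on this read-out higher numbers stand for a stronger effect at the one concentration tested and lower numbers for a weaker effect. Compound 1 `N#CC1=C(N)N(c2ccc(S(N)(=O)=O)cc2)C2=C(C(=O)CCC2)C1/C=C/c1ccccc1` carries a 2-phenylethenyl group on a saturated ring carbon, and in this assay compound 1 gives 45%. Compound 2 `COc1cc(CC2C(C#N)=C(N)N(c3ccc(S(N)(=O)=O)cc3)C3=C2C(=O)CCC3)ccc1O` carries a 4-hydroxy-3-methoxybenzyl group at that position, and in this assay compound 2 gives 100%. Compound 3 `N#CC1=C(N)N(c2ccc(S(N)(=O)=O)cc2)C2=C(C(=O)CCC2)C1c1ccco1` carries a furan-2-yl group there, and in this assay compound 3 gives 10%. Within the data shown here, compound 3 thus stands lowest of the three: the change a number 35 percentage points lower from compound 1 to compound 3 (beyond the scatter) and the change a number 90 percentage points lower from compound 2 to compound 3 (beyond the scatter) both run downward and both lie beyond the scatter, while a number 55 percentage points higher from compound 1 to compound 2 (beyond the scatter) is the one upward step among them.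

Compound 4 `N#CC1=C(N)N(c2ccc(S(N)(=O)=O)cc2)C2=C(C(=O)CCC2)C1c1cccs1` has not yet been measured. It differs from compound 3 in one place: thiophen-2-yl in place of furan-2-yl on a saturated ring carbon. Among the measured compounds shown here, none of the measured steps exchanges one five-membered aromatic ring with 1 hetero atom for another; each of them swaps in a group of quite different shape, and each was large. So there is no direct guide, and the expectation rests on compound 3 alone. Because compound 3 gives 10%, the step expected for compound 4 is small, a number 8 percentage points higher from compound 3 to compound 4 (within the scatter), and likely within the scatter. The estimated result for compound 4 in this assay is 18%, with a range from 4% to 50%.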

Compound 4, a percentage reported as activity, at one concentration (the size of the read-out at that concentration, not a potency): 100%
Compound 4: the middle estimate sits 82 percentage points below what was measured; measured number above the stated range.
By their numbers in this assay, from the lowest: compound 3; then compound 1; then compounds 2 and 4 (each within the scatter of the next).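

At this saturated ring carbon, exchanging one five-membered aromatic ring with 1 hetero atom for another, with the same counts of heavy atoms, donors and acceptors, still moves the result in this assay by a large amount: a number 90 percentage points higher from compound 3 to compound 4 (beyond the scatter). Exchanging sulfur for oxygen in the ring is enough to separate a weak number from a strong one. The 4-hydroxy-3-methoxybenzyl group is not needed for a high number, with no change at the digits printed from compound 2 to compound 4 (within the scatter) and a number 55 percentage points higher from compound 1 to compound 4 (beyond the scatter). The data shown include no measurement that would explain this difference between thiophen-2-yl and furan-2-yl.

Going by these compounds, compound 2 gives 100% and compound 4 gives 100%, but a reading at one concentration is not a potency, so how these two compare at lower concentrations remains open. On these data alone, it is also open whether other groups on this carbon, such as phenyl, pyridin-3-yl, an amine or a longer alkyl chain, would give results closer to compound 4 or to compound 3.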